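The source may report more compounds than this note shows. Statements on the series, on what has been measured and on what is new or still open speak of the compounds shown alone.

Compound 3 `Cc1ccc(COc2ccc(C(=O)NC(=S)Nc3ccc(C)c(-c4nc5ccccc5[nH]4)c3)cc2)cc1` was tested in a functional assay on MNK45 cells (Homo sapiens) for inhibition, read by MTT assay, with a stated time of 48 h (on this read-out higher numbers stand for weaker inhibition and lower numbers for stronger inhibition), where compound 3 gives 11300 nM. That number lies close to compound 2 `Cc1ccc(NC(=S)NC(=O)c2ccc(OCc3ccc(C(F)(F)F)cc3)cc2)cc1-c1nc2ccccc2[nH]1`, which in this assay gives 10200 nM, the two being separated by a 1.1-fold higher number from compound 2 to compound 3 (0.04 log units; within the scatter). Both stand well apart from compound 1 `Cc1ccc(NC(=S)NC(=O)c2ccc(OCc3cccc(Cl)c3)cc2)cc1-c1nc2ccccc2[nH]1`, which gives 43300 nM in this assay; the measured steps are a 3.8-fold lower number from compound 1 to compound 3 (0.58 log units; beyond the scatter) and a 4.2-fold lower number from compound 1 to compound 2 (0.63 log units; beyond the scatter).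

Compound 4 `Cc1ccc(NC(=S)NC(=O)c2ccc(OCc3ccccc3Cl)cc2)cc1-c1nc2ccccc2[nH]1` has not yet been measured. Compound 4 differs from compound 3 by 2-chlorophenyl in place of 4-methylphenyl on a saturated chain carbon bound to an oxygen on an aromatic ring. Among the measured compounds shown here, no measured step moves a chlorine from one place on this ring to another, so the only guides are a 3.8-fold lower number from compound 1 to compound 3 (0.58 log units; beyond the scatter) and a 4.2-fold lower number from compound 1 to compound 2 (0.63 log units; beyond the scatter), both modest. These show that changing the substituent on this ring can shift the number noticeably, and the direction for a 2-chlorophenyl cannot be read from the data. Compound 4 is therefore expected to give roughly 22000 nM in this assay, with a likely range from 7000 nM to 70000 nM. The estimated step is a 1.9-fold higher number from compound 3 to compound 4 (0.29 log units; within the scatter).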

Compound 4, half-maximal inhibitory concentration: 51400 nM
Compound 4: middle estimate off by 2.3-fold (0.37 log units), on the low side; low and high end bracket the measured number.
By their numbers in this assay, from the lowest: compounds 2 and 3 (each within the scatter of the next); then compounds 1 and 4 (each within the scatter of the next).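

In this assay, putting 2-chlorophenyl on the saturated chain carbon weakens inhibition against both earlier low-number compounds, with a 4.5-fold higher number from compound 3 to compound 4 (0.66 log units; beyond the scatter) and a 5.0-fold higher number from compound 2 to compound 4 (0.70 log units; beyond the scatter). The swap of 3-chlorophenyl for 2-chlorophenyl, by contrast, stays within the scatter at a 1.2-fold higher number from compound 1 to compound 4 (0.07 log units; within the scatter), so among these four compounds the two chlorophenyl groups sit together at the high numbers, 4-methylphenyl and 4-(trifluoromethyl)phenyl sit together at the low numbers, and no compound shown goes against this split. No measurement here offers a reason for this split.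

The compounds shown do not separate the chlorine from its place on the ring: none carries chlorine where 4-methylphenyl carries its methyl. Also open, on these data alone, is how a phenyl ring with no substituent, or one bearing an amine or a carboxylic acid, would read at this position.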